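This account rests on a few compounds, and the source may have more. Where it says the series, first, only, none or still open, it means among the compounds named here.

Compound 3, `O=C(O)/C=C/c1c(Cn2c(=O)n(C3CC3)c3ccncc32)nc2cc(Cl)ccn12`, carries a 2-carboxyethenyl group on the shared core. In an ADME assay on HEp-2 cells (Homo sapiens) for cytotoxicity, read by CCK-8 assay, with a stated time of 6 days (a higher number here means that more compound is tolerated, a lower number that less compound is tolerated), compound 3 gives > 100000 nM, which is a limit of the assay rather than a number. Two close relatives stand at the same point. Compound 1, `O=c1n(Cc2nc3cc(Cl)ccn3c2CCCCO)c2cnccc2n1C1CC1`, gives > 100000 nM in this assay, again a limit. Compound 2, `O=C(NCCO)c1c(Cn2c(=O)n(C3CC3)c3ccncc32)nc2cc(Cl)ccn12`, gives > 100000 nM in this assay, also a limit. Because every value sits at the limit of > 100000 nM in this assay, at which 3 of the 3 values shown sit, the steps between these compounds cannot be read: a step that the two limits leave unreadable from compound 1 to compound 2, a step that the two limits leave unreadable from compound 1 to compound 3 and a step that the two limits leave unreadable from compound 2 to compound 3 are all hidden behind the limit. The next compound, compound 4, `NC(=O)CCc1c(Cn2c(=O)n(C3CC3)c3ccncc32)nc2cc(Cl)ccn12`, differs from compound 3 in one place: 2-carbamoylethyl in place of 2-carboxyethenyl on an aromatic carbon. Among the compounds with values here, no measured step bears on this change in a readable way; all three steps among compounds 1, 2 and 3 are unreadable. What the data do show is that three different groups at this place, the 4-hydroxybutyl, the (2-hydroxyethyl)carbamoyl and the 2-carboxyethenyl, all leave the compound tolerated up to the limit. The expectation for compound 4 is therefore that the step of a number no higher from compound 3 to compound 4 (the limit leaves the size open) will be no change beyond the scatter and that the readout will most likely be a limit again. Compound 4 is estimated at 100000 nM, with a range from 50000 nM to 200000 nM.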

Compound 4, half-maximal cytotoxic concentration: > 100000 nM
Compound 4: only a limit was reported; the forecaster's own chance of this, stated with the estimate: 85%; the middle value sits exactly at the limit.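

In this assay compound 4 gives > 100000 nM and this is a limit, not a number. The steps joining compound 4 to compound 1, compound 2 and compound 3 cannot be read, because all the values sit at one point: the limit of > 100000 nM in this assay, at which 4 of the 4 values shown sit. The compounds shown leave open how far beyond this limit each one is tolerated, and whether any group at this place would lower the value.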